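The source may report more compounds than this note shows. Statements on the series, on what has been measured and on what is new or still open speak of the compounds shown alone.

In an ADME assay on the whole organism (plasma, Rattus norvegicus, strain Sprague-Dawley) for pharmacokinetics, read by LC-MS, with a stated time of 4 h, at a dose of 15 mg/kg by the intraduodenal route (on this read-out higher numbers stand for higher exposure at the dose given and lower numbers for lower exposure), two compounds have been measured so far. Compound 1 `C=C[C@@H]1C[C@]1(NC(=O)[C@@H]1C[C@@H](Oc2nccc3cc(OC)ccc23)CN1C(=O)[C@@H](NC(=O)N[C@H](C(=O)O)C(C)(C)C)C(C)(C)C)C(=O)NS(=O)(=O)C1CC1` gives 91 ng.h/mL and compound 2 `C=C[C@@H]1C[C@]1(NC(=O)[C@@H]1C[C@@H](Oc2cc(-c3ccccc3)nc3cc(OC)ccc23)CN1C(=O)[C@@H](NC(=O)OC(C)(C)C)C(C)(C)C)C(=O)NS(=O)(=O)C1CC1` gives 61 ng.h/mL, so compound 2 stands within the usual scatter of compound 1. These two compounds differ in more than one place, and no single change can be read from their values. Compound 3 `C=C[C@@H]1C[C@]1(NC(=O)[C@@H]1C[C@@H](Oc2cc(-c3ccccc3)nc3cc(OC)ccc23)CN1C(=O)[C@@H](NC(=O)NC(C)(C)C)C(C)(C)C)C(=O)NS(=O)(=O)C1CC1` is compound 2 with (tert-butyl)amino in place of tert-butoxy on a carbonyl carbon. Among the measured compounds shown here, no measured pair shows this exchange on its own, so no step beyond the scatter is expected in this assay, and neither direction is favoured. The expected change is small, a 1.0-fold lower number from compound 2 to compound 3 (0.01 log units; within the scatter). This expectation rests on compound 2 at 61 ng.h/mL. Compound 3 is estimated at 60 ng.h/mL, with an expected range from 20 ng.h/mL to 180 ng.h/mL.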

Compound 3, area under the concentration-time curve: 17 ng.h/mL
Estimate against measurement, compound 3: 3.5-fold (0.55 log units) above, and the stated range ends above it.
By their numbers in this assay, from the lowest: compound 3; then compounds 2 and 1 (each within the scatter of the next).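

In this assay, among the compounds shown here, (tert-butyl)amino in place of tert-butoxy on a carbonyl carbon gives a 3.6-fold lower number from compound 2 to compound 3 (0.55 log units; beyond the scatter), the only single change that can be read so far. The exposure at this position is therefore not indifferent to the exchange, even though both groups have the same count of heavy atoms and differ only in nitrogen for oxygen, with a hydrogen-bond donor entering and a hydrogen-bond acceptor leaving. Nothing at hand bears on why the number changes with this exchange.

The compounds shown leave open whether the same exchange gives a step of this size on another core. They also leave open how a cyclopentyloxy group or a (tert-butyl)(methyl)amino group on the same carbonyl carbon would read.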